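Swapping a Triple Bond for a Double Bond

The compounds below may be only part of what the source reports. "The series", "measured", "known", "first", "only" and "open" are said of these compounds alone.

Compound 1 `CNC1(COc2cccnc2)CC1` gives 3 nM in an assay on brain for displacement of a labelled ligand from Neuronal acetylcholine receptor; alpha4/beta2 (Rattus norvegicus); on this read-out higher numbers stand for weaker inhibition and lower numbers for stronger inhibition.
Compound 2 `C#Cc1cncc(OCC2(NC)CC2)c1` gives 6.56 nM in this assay.

Compound 2 stands at the higher of these two numbers. Among the compounds with values here, the single measured step, a 2.2-fold higher number from compound 1 to compound 2 (0.34 log units; beyond the scatter), is modest. Compound 3 `C=Cc1cncc(OCC2(NC)CC2)c1` differs from compound 2 by vinyl in place of ethynyl on an aromatic carbon. Within the data shown here, no measured step covers this exact exchange; the one available step only shows that placing ethynyl on this carbon shifts the number modestly. Vinyl and ethynyl match in heavy-atom count, so the expected step of a 1.1-fold lower number from compound 2 to compound 3 (0.04 log units; within the scatter) is small, probably within the scatter. Compound 3 is estimated at 6 nM, within a range from 2 nM to 18 nM.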

Compound 3, inhibition constant: 70.1 nM
For compound 3 the middle estimate is 12-fold (1.07 log units) below the measured one; the measured number lies above the stated range.
By their numbers in this assay, from the lowest: compound 1; then compound 2; then compound 3.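

Ethynyl and vinyl have the same heavy-atom count, yet they are not interchangeable on this aromatic carbon: an 11-fold higher number from compound 2 to compound 3 (1.03 log units; beyond the scatter) is a large step towards weaker inhibition. The earlier compounds shown here showed only a modest shift with ethynyl here, whereas vinyl goes much further, with a 23-fold higher number from compound 1 to compound 3 (1.37 log units; beyond the scatter) compared with hydrogen on the same carbon. Nothing available explains this gap between the triple and double bonds. On these data alone, whether a nitrile or an ethyl group on this carbon would sit closer to ethynyl or to vinyl remains open.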